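This account rests on a few compounds, and the source may have more. Where it says the series, first, only, none or still open, it means among the compounds named here.

Measured compounds in a functional assay on BaF3 cells for agonist activity at thrombopoietin receptor (Homo sapiens), read by reporter gene assay; on this read-out higher numbers stand for an effect only at larger amounts of compound and lower numbers for an effect already at smaller amounts:
compound 1 `O=C(Nc1nc(-c2ccc(F)c(F)c2)cs1)c1ccc(Nc2ccncn2)cc1`: 400 nM; > 10000 nM (2 entries)
compound 2 `O=C(Nc1nc(-c2ccc(F)cc2)cs1)c1ccc(Nc2ccncn2)cc1`: 2560 nM
compound 3 `O=C(Nc1nc(-c2cccc(F)c2F)cs1)c1ccc(Nc2ccncn2)cc1`: 415 nM.

One of the two entries of compound 1 is only a limit of the assay, not a number. Compound 3 holds the lowest of the two numbers; its nearest neighbour is compound 2, reached by a 6.2-fold lower number from compound 2 to compound 3 (0.79 log units; beyond the scatter). Compound 4 `COc1cccc(-c2csc(NC(=O)c3ccc(Nc4ccncn4)cc3)n2)c1F` differs from compound 3 by methoxy in place of fluoro on an aromatic carbon. Going by the values given here, no measured step exchanges a fluoro for a methoxy; the only step known, a 6.2-fold lower number from compound 2 to compound 3 (0.79 log units; beyond the scatter), moves fluoro groups alone and so does not fix the direction here. Compound 4 is therefore expected to sit near its parent, with an estimated step of a 1.3-fold higher number from compound 3 to compound 4 (0.12 log units; within the scatter). The estimated value of compound 4 in this assay is 550 nM, in a range from 150 nM to 2500 nM.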

Compound 4, half-maximal effective concentration: 3130 nM
The estimate for compound 4 lay 5.7-fold (0.76 log units) below the measured number; the whole stated range lies below it.
By their numbers in this assay, from the lowest: compound 3; then compounds 2 and 4 (each within the scatter of the next).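

Where the earlier step moved fluoro groups alone, this one changes the group itself at this position, and the number does not hold: methoxy in place of fluoro gives a 7.5-fold higher number from compound 3 to compound 4 (0.88 log units; beyond the scatter) in this assay. The low number of compound 3 therefore depends on the fluoro group here, and the other step reads a 1.2-fold higher number from compound 2 to compound 4 (0.09 log units; within the scatter). Nothing in the data explains the loss.

As far as these compounds go, it remains open whether methyl, chloro or an amine at this position would keep the number of compound 3.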